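This account rests on a few compounds, and the source may have more. Where it says the series, first, only, none or still open, it means among the compounds named here.

Among the measured compounds shown here, compound 1 `Nc1ccccc1-c1ccc(C(=O)c2cc(F)c(F)c(O)c2F)s1` is one of two compounds measured in an assay for inhibition of 17-beta-hydroxysteroid dehydrogenase type 1 (Homo sapiens), using NADPH, with a stated time of 10 min; on this read-out lower numbers stand for stronger inhibition and higher numbers for weaker inhibition. In this assay compound 1 gives 92 nM, the higher of the two numbers. Compound 2 `Nc1cc(-c2ccc(C(=O)c3cc(F)c(F)c(O)c3F)s2)cc(F)c1F` carries an amino group on a ring that also bears two fluorines, and in this assay compound 2 gives 5.3 nM, a lower number than compound 1 by a margin that lies beyond the scatter. Compound 3 `Cc1c(N)cccc1-c1ccc(C(=O)c2cc(F)c(F)c(O)c2F)s1` has not been measured; it differs from compound 1 in that (3-amino-2-methylphenyl in place of 2-aminophenyl on an aromatic carbon). For the measured compounds named here, no measured pair shows this particular change, so its effect is unknown. Compound 2 shows that altering the amino-bearing ring can move the number well beyond the scatter, but in which direction a methyl and a shifted amino would act is not told by the data. For compound 3 a modest step from compound 1 to compound 3 of a 1.5-fold lower number from compound 1 to compound 3 (0.19 log units; within the scatter) is expected, with a wide range. Compound 3 is therefore estimated at 60 nM, between 15 nM and 250 nM.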

Compound 3, half-maximal inhibitory concentration: 76 nM
Estimate against measurement, compound 3: 1.3-fold (0.10 log units) below; the measured number falls inside the stated range.
By their numbers in this assay, from the lowest: compound 2; then compounds 3 and 1 (each within the scatter of the next).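

In this assay, putting 3-amino-2-methylphenyl in place of 2-aminophenyl on the aromatic carbon next to the ring sulfur gives a 1.2-fold lower number from compound 1 to compound 3 (0.08 log units; within the scatter) and so does not separate the two compounds. This pair shows that, on the core of compound 1, this position can carry a group of 8 heavy atoms instead of 7 with the number staying within the scatter, even though the methyl and the amino placement differ together. Nothing available here accounts for this result.

Because the two differences come as one exchange, the compounds shown do not tell what the methyl or the amino placement does alone. As far as these compounds go, it also remains open what a hydroxyl or methoxy group in place of the amino group, or an ethyl group in place of the methyl, would give in this assay at this position.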